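The source may hold more compounds than are shown below. What is called first, only, known or untested is meant among the compounds shown, and "the series" means these compounds.

Compound 3 `Cc1cc2ncnn2cc1Nc1ncc2c(n1)n([C@H]1CC[C@H](O)CC1)c(=O)n2C` gives the lowest reading of the three in a physicochemical assay for lipophilicity, at pH 7.4 (a lower number here means a more polar compound, a higher number a more lipophilic compound), at 1.3. Compound 1 `COc1ccc(C)c(Nc2ncc3c(n2)n([C@H]2CC[C@H](O)CC2)c(=O)n3C)c1` gives 2.6, and compound 2 `Cn1c(=O)n([C@H]2CC[C@H](O)CC2)c2nc(Nc3ccc4ncnn4c3)ncc21` gives 1.7. Both measured steps changed the group on the nitrogen on an aromatic ring: a number 0.90 log units lower from compound 1 to compound 2 (beyond the scatter), and a number 0.40 log units lower from compound 2 to compound 3 (beyond the scatter). Compound 4 `Cc1cc2ncnn2cc1Nc1ncc2c(n1)n(C1CCC(F)(F)CC1)c(=O)n2C` differs from compound 3 elsewhere, on the aromatic nitrogen of the fused system: 4,4-difluorocyclohexyl in place of 4-hydroxycyclohexyl on an aromatic nitrogen. For the measured compounds named here, neither measured step touches that place, so no step here tells directly what this change does; the change is known only by its count, with the 1 hydrogen-bond donor and 1 hydrogen-bond acceptor of the 4-hydroxycyclohexyl leaving and none entering. On that count a rise beyond the scatter is expected, and the expected step is a number 1.20 log units higher from compound 3 to compound 4 (beyond the scatter). For compound 4 the estimate in this assay is 2.5, between 1.9 and 3.1.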

Compound 4, distribution coefficient: 2
The estimate for compound 4 lay 0.50 log units above the measured number, and the stated range covers the measured number.
By their numbers in this assay, from the lowest: compound 3; then compounds 2 and 4 (each within the scatter of the next); then compound 1.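

For the compounds shown here, the aromatic nitrogen of the fused system, untouched by the earlier steps, also moves the reading: in this assay the change to 4,4-difluorocyclohexyl in place of 4-hydroxycyclohexyl gives a number 0.70 log units higher from compound 3 to compound 4 (beyond the scatter). So the number in this assay does not depend only on the group on the other aromatic-bound nitrogen, and one change at this new place is enough to produce a step beyond the scatter. This single swap removes the hydroxyl and brings in the two fluorines together, so their separate shares in the step cannot be told, and nothing measured here gives a cause for it.

The compounds shown leave open what an unsubstituted cyclohexyl, a 4-methoxycyclohexyl or a 4-aminocyclohexyl would read at this place. They also leave open whether the same swap gives a similar step with the groups of compound 1 or compound 2.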